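A Methoxy Swap Among Compounds Known Only by Limits

A few compounds are considered here, and "the series" means these few. Any claim that something is new, unique, unknown or untested is made for them only; others in the source may bear on it.

Compound 2 (`Clc1cccc(Cn2cnc3c(-c4ccco4)ncnc32)c1`) has no exact number in a functional assay on Vero cells (Chlorocebus sabaeus) for inhibition; a higher number here means a weaker inhibitor, a lower number a stronger inhibitor. Compound 2 gives > 10 ug/mL, which is a limit. Compound 3 (`Fc1ccc(Cn2cnc3c(-c4ccco4)ncnc32)cc1`) gives > 10 ug/mL, also a limit. Compound 1 (`Clc1ccc(Cn2cnc3c(-c4ccco4)ncnc32)cc1`) gives > 62.5 ug/mL, again a limit. Compound 4 (`COc1cccc(Cn2cnc3c(-c4ccco4)ncnc32)c1`) differs from compound 2 by one change: methoxy in place of chloro on an aromatic carbon. The closest guides are a step that the two limits leave unreadable from compound 1 to compound 2 and a step that the two limits leave unreadable from compound 2 to compound 3, and neither has a size that can be read. The limits themselves are the limit of > 10 ug/mL in this assay, at which 2 of the 3 values shown sit, and (the limit of > 62.5 ug/mL in this assay, at which 1 of the 3 values shown sits). No direction can therefore be drawn from them, and a value in the same region as its relatives is expected. The expected change is a step that the limit leaves unreadable from compound 2 to compound 4. For compound 4 the estimate is 20 ug/mL, with an expected range from 7 ug/mL to 62.5 ug/mL.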

Compound 4, half-maximal inhibitory concentration: > 625 ug/mL
Compound 4 was reported as a limit (the forecaster's own chance of this, stated with the estimate: 75%); middle value at least 31-fold (1.49 log units) from the limit.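

Compound 2 and compound 4 are both known only by limits, and the step between them, methoxy in place of chloro, cannot be read. The compounds shown leave open how strongly each one inhibits: none carries an exact value.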